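The source may hold more compounds than are shown below. What is called first, only, known or untested is meant among the compounds shown, and "the series" means these compounds.

Series notes. Compound 3 `CC(C(=O)NCc1ccc(C(F)(F)F)nc1C1CCC(C)(C)CC1)c1ccc(NS(C)(=O)=O)c(F)c1` stands lowest of the three in an assay on CHO cells for antagonist activity at transient receptor potential cation channel subfamily V member 1 (Homo sapiens), read by FLIPR and calcium flux (a higher number here means a weaker inhibitor, a lower number a stronger inhibitor), giving 0.4 nM; compound 2 `CC(C(=O)NCc1ccc(C(F)(F)F)nc1CCC(C)(C)C)c1ccc(NS(C)(=O)=O)c(F)c1` gives 0.6 nM, and compound 1 `CC(C(=O)NCc1ccc(C(F)(F)F)nc1Br)c1ccc(NS(C)(=O)=O)c(F)c1` gives 169 nM. The gap a 1.5-fold lower number from compound 2 to compound 3 (0.18 log units; within the scatter) lies within the scatter, whereas a 420-fold lower number from compound 1 to compound 3 (2.63 log units; beyond the scatter) and a 280-fold lower number from compound 1 to compound 2 (2.45 log units; beyond the scatter) are large. Compound 4 `CC1C=C(c2nc(C(F)(F)F)ccc2CNC(=O)C(C)c2ccc(NS(C)(=O)=O)c(F)c2)CCC1` carries the change (3-methylcyclohex-1-en-1-yl in place of 4,4-dimethylcyclohexyl on an aromatic carbon). Within the data shown here, the steps that bear on it, a 420-fold lower number from compound 1 to compound 3 (2.63 log units; beyond the scatter) and a 1.5-fold lower number from compound 2 to compound 3 (0.18 log units; within the scatter), show that a bulky carbon ring or chain at this position sits far below the bromo compound 1, and that the cyclohexyl and the chain differ only within the scatter. A step of no more than scatter size, a 1.5-fold higher number from compound 3 to compound 4 (0.18 log units; within the scatter), is therefore expected in this assay. The value of compound 4 is estimated at 0.6 nM, within 0.2 nM to 2 nM.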

Compound 4, inhibition constant: 0.2 nM
Estimate against measurement, compound 4: 3.0-fold (0.48 log units) above, and the stated range covers the measured number.
By their numbers in this assay, from the lowest: compounds 4, 3 and 2 (each within the scatter of the next, the first and the last beyond it); then compound 1.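

In this assay the 3-methylcyclohex-1-en-1-yl group holds up as well as 4,4-dimethylcyclohexyl, with a 2.0-fold lower number from compound 3 to compound 4 (0.30 log units; within the scatter), so a ring double bond and one fewer carbon are tolerated at this position. Among the carbon groups, a first modest separation appears with a 3.0-fold lower number from compound 2 to compound 4 (0.48 log units; beyond the scatter), and the large gap to the bromo compound persists with an 850-fold lower number from compound 1 to compound 4 (2.93 log units; beyond the scatter). No evidence is available on what lies behind these differences. Still open, going by these compounds, is how a ring bearing an amine or a carboxylic acid would fare here. On these data alone, the effect of an aromatic phenyl ring at this position is also open.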